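A few compounds are considered here, and "the series" means these few. Any claim that something is new, unique, unknown or untested is made for them only; others in the source may bear on it.

Compound 3, `CCCCCCCCCCCC(=O)OC[C@H](CSC[C@@H](N)C(=O)NCCCCCCCCCC(=O)O)OC(=O)CCCCCCCCCCC`, belongs to a small set of three dipalmitoyl-type thioether lipopeptides that share one core and differ only in the group on the amide-type nitrogen. In an assay on HEK293 cells for agonist activity at Toll-like receptor 2 (Homo sapiens) (a lower number here means that less compound is needed, a higher number that more compound is needed for the effect), compound 3 gives 4400 nM, the second highest of the three numbers. Compound 1, `CCCCCCCCCCCC(=O)OC[C@H](CSC[C@@H](N)C(=O)NC1(CO)CC1)OC(=O)CCCCCCCCCCC`, gives 265 nM in this assay, and compound 2, `CCCCCCCCCCCC(=O)OC[C@H](CSC[C@@H](N)C(=O)NCCCS(=O)(=O)O)OC(=O)CCCCCCCCCCC`, gives 5560 nM. The two large steps run from the hydroxymethylcyclopropyl amide to the 3-sulfopropyl and 9-carboxynonyl groups: a 21-fold higher number from compound 1 to compound 2 (1.32 log units; beyond the scatter) and a 17-fold higher number from compound 1 to compound 3 (1.22 log units; beyond the scatter). Between these two chains the step is small, a 1.3-fold lower number from compound 2 to compound 3 (0.10 log units; within the scatter).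

Compound 4, `CCCCCCCCCCCC(=O)OC[C@H](CSC[C@@H](N)C(=O)NCCCN)OC(=O)CCCCCCCCCCC`, is reached from compound 3 by the change (amino in place of 6-carboxyhexyl on a saturated chain carbon, three bonds along the chain from an amide-type nitrogen). The step that bears most directly on this position, compound 2 to compound 3, shows that swapping one end group for another leaves the number essentially unchanged, whereas the steps from compound 1 show that the amide substituent can move the number substantially. Compound 4 carries an amino group rather than a 6-carboxyhexyl end, so a move back toward the number of compound 1 is expected, though with wide uncertainty: the step of a 7.3-fold lower number from compound 3 to compound 4 (0.87 log units; beyond the scatter) is estimated. For compound 4 an estimate of 600 nM is therefore given, with a range from 120 nM to 3500 nM.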

Compound 4, half-maximal effective concentration: 1960 nM
The estimate for compound 4 lay 3.3-fold (0.51 log units) below the measured number, within the range that was stated.
By their numbers in this assay, from the lowest: compound 1; then compound 4; then compounds 3 and 2 (each within the scatter of the next).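

In this assay, the group at the end of the chain does move the number, which the earlier exchange of sulfo for 6-carboxyhexyl did not show (a 1.3-fold lower number from compound 2 to compound 3 (0.10 log units; within the scatter)). Amino gives a lower number than 6-carboxyhexyl (a 2.2-fold lower number from compound 3 to compound 4 (0.35 log units; beyond the scatter)) and also than sulfo (a 2.8-fold lower number from compound 2 to compound 4 (0.45 log units; beyond the scatter)), and the second comparison is the closer one, since the chain from the amide-type nitrogen stays the same while only the end group changes. Even so, the amino end closes only part of the distance to the 1-(hydroxymethyl)cyclopropyl amide (a 7.4-fold higher number from compound 1 to compound 4 (0.87 log units; beyond the scatter)), and nothing shown gives a reason for any of these differences.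

The compounds shown leave open how much of the step from compound 3 to compound 4 belongs to the end group and how much to the shorter chain, as a carboxylic acid on the three-carbon chain or an amine on the longer chain would separate the two. They also leave open whether a hydroxyl on the same chain, closer to the hydroxymethyl of compound 1, would bring the number nearer to that of compound 1.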